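Dichlorophenyl for methoxyphenyl on the sulfonyl sulfur

The source may report more compounds than this note shows. Statements on the series, on what has been measured and on what is new or still open speak of the compounds shown alone.

Compound 1 `CC1CCN(c2c(S(=O)(=O)c3ccc(Cl)c(Cl)c3)cnc3cc(F)ccc23)CC1`, compound 2 `COc1ccc(S(=O)(=O)c2cnc3cc(F)ccc3c2N2CCC(C)CC2)cc1` and compound 3 `COc1ccc(S(=O)(=O)c2cnc3ccc(F)cc3c2N2CCC(C)CC2)cc1` have been measured in an assay on isolated protein for displacement of a labelled ligand from metabotropic glutamate receptor 5 (Homo sapiens), with a stated time of 60 min, tested at 1 uM; on this read-out lower numbers stand for less inhibition and higher numbers for more inhibition at the one concentration tested (going by the name of the read-out). In this assay compound 1 gives 94%. In this assay compound 2 gives 90%, and compound 3 gives 85%. All three numbers lie within the usual scatter of one another, so no order among them is claimed.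

Compound 1 and compound 2 differ in one place: 3,4-dichlorophenyl in place of 4-methoxyphenyl on a sulfonyl sulfur. This change made a number 4 percentage points higher from compound 2 to compound 1 (within the scatter), a step within the scatter.

Compound 2 and compound 3 have the same atoms joined differently; the difference between the two cores is not broken down here. Their values in this assay sit within the scatter of each other.

Compound 4 `CC1CCN(c2c(S(=O)(=O)c3ccc(Cl)c(Cl)c3)cnc3ccc(F)cc23)CC1` is not yet measured. It stands to compound 3 as compound 1 stands to compound 2: 3,4-dichlorophenyl in place of 4-methoxyphenyl on a sulfonyl sulfur. The place of the change reads the same for both pairs, so this is the same change, occurring twice among these compounds. Among the compounds with values here, only one measured instance of it exists, and that step lies within the scatter, so the expectation rests on that single step together with the value of compound 3. The estimated step in this assay is a number 3 percentage points higher from compound 3 to compound 4 (within the scatter), beside the measured a number 4 percentage points higher from compound 2 to compound 1 (within the scatter). The starting point is compound 3 with its 85% in this assay. Compound 4 is therefore expected to give 88% in this assay, with a likely range from 78% to 96%.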

Compound 4, a percentage reported as inhibition, at one concentration (the size of the read-out at that concentration, not a potency): 91%
Compound 4: the middle estimate sits 3 percentage points below what was measured, and the stated range covers the measured number.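

On the second core, the change from 4-methoxyphenyl to 3,4-dichlorophenyl on the sulfonyl sulfur gives a number 6 percentage points higher from compound 3 to compound 4 (within the scatter) in this assay. Set beside the earlier step, the change shows no difference between the two cores: the same change on two cores in this assay, a number 4 percentage points higher (within the scatter) from compound 2 to compound 1 and a number 6 percentage points higher (within the scatter) from compound 3 to compound 4, 2 percentage points apart, within the scatter of two such steps This supports only a limited statement: on both cores the exchange leaves the read-out within the scatter, so it does not show that the change increases inhibition on either core, and a reading at one concentration gives no potency, so any difference in potency between these pairs would remain unseen.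

In the compounds shown, the sulfonyl sulfur carries only a substituted phenyl ring, so it remains open whether the same small steps would hold with a propyl chain on the sulfur, or with a carboxylic acid or a primary amine on the phenyl ring. Also open, from the compounds shown here alone, is whether the two cores would continue to match in this assay with a group other than 3,4-dichlorophenyl or 4-methoxyphenyl, since two pairs carrying one exchange are too few to establish a rule for the series.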